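Trifluoroethoxy to methoxy on a second hydrazide core

The source may report more compounds than this note shows. Statements on the series, on what has been measured and on what is new or still open speak of the compounds shown alone.

Measured compounds:
compound 1 `COc1ccc(C2CC2C(=O)NNc2nncc3ccccc23)cc1` gives 96000 nM
compound 2 `O=C(NNc1nncc2ccccc12)C1CC1c1ccc(OCC(F)(F)F)cc1` gives 48000 nM
compound 3 `O=C(NNC(=O)C1CC1c1ccc(OCC(F)(F)F)cc1)c1ccncc1` gives 10000 nM

Of the compounds shown here, three have been tested in a functional assay on A549 cells (Homo sapiens) for inhibition, read by MTT assay, with a stated time of 72 h; a lower number here means a stronger inhibitor, a higher number a weaker inhibitor. Compound 1 and compound 2 share one core, and there compound 1 differs from compound 2 in one place: hydrogen in place of trifluoromethyl on a saturated chain carbon bound to an oxygen on an aromatic ring. This step, a 2.0-fold higher number from compound 2 to compound 1 (0.30 log units; within the scatter), hardly moved the number. Compound 3 stands on a second core, and the difference between the two cores is not broken down here; in this assay compound 3 gives the lowest of the three values, with compound 2 next and compound 1 furthest away.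

Compound 4 `COc1ccc(C2CC2C(=O)NNC(=O)c2ccncc2)cc1` is not yet measured. It differs from compound 3 in the same way, (hydrogen in place of trifluoromethyl on a saturated chain carbon bound to an oxygen on an aromatic ring), as compound 1 differs from compound 2. The step from compound 3 to compound 4 is expected to be about as small as the one already seen, because a 2.0-fold higher number from compound 2 to compound 1 (0.30 log units; within the scatter) lay within the scatter, so an estimated 2.0-fold higher number from compound 3 to compound 4 (0.30 log units; within the scatter) is anticipated. The value of compound 4 in this assay is estimated at 20000 nM, likely between 7000 nM and 55000 nM.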

Compound 4, half-maximal inhibitory concentration: > 100000 nM
Compound 4: a limit, no number (the forecaster's own chance of this, stated with the estimate: 10%); middle value at least 5.0-fold (0.69 log units) from the limit.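

In this assay compound 4 gives > 100000 nM, which is a limit of the assay and not a number. On the core of compound 3, the change from 2,2,2-trifluoroethoxy to methoxy gives an at least 10-fold higher number from compound 3 to compound 4 (1.00 log units; beyond the scatter), so the size of this step did not carry over from the core of compound 1 and compound 2: the same change on two cores in this assay, a 2.0-fold higher number (0.30 log units; within the scatter) from compound 2 to compound 1 and an at least 10-fold higher number (1.00 log units; beyond the scatter) from compound 3 to compound 4, at least 5.0-fold (0.69 log units) apart, beyond the scatter of two such steps This shows that the step depends on the core in these four compounds, but it does not give the true size of the step or explain the gap, and one pair on each core sets no rule for the series, as the limit marks only where the reading stops: the limit of > 100000 nM in this assay, at which 1 of the 4 values shown sits.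

The compounds shown leave open how the assay would respond to other groups in the same place, such as a longer chain, an amine or a carboxylic acid in place of trifluoromethyl. They also leave open whether a third core would follow the pair of compound 1 and compound 2 or the pair of compound 3 and compound 4.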